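The compounds below may be only part of what the source reports. "The series", "measured", "known", "first", "only" and "open" are said of these compounds alone.

In a physicochemical assay for solubility, in phosphate buffer, at pH 7.4 (a higher number here means a more soluble compound, a lower number a less soluble compound), compound 1 `CC(=O)N[C@@H]1CCC[C@H](C(=O)Nc2cc(-c3cnn4c3CCCC4)c(F)cn2)C1` reports only a limit, > 1000000 nM. Compound 2 `CC(=O)N[C@@H]1CCC[C@H](C(=O)Nc2cc(-c3cnn4c3CCCC4)c(Cl)cn2)C1` gives 310000 nM, and compound 3 `CC(=O)N[C@@H]1CCC[C@H](C(=O)Nc2cc(-c3nnn4ccccc34)c(Cl)cn2)C1` gives 530000 nM. Chloro in place of fluoro on an aromatic carbon gives an at least 3.2-fold lower number from compound 1 to compound 2 (0.50 log units; beyond the scatter). Exchanging the nine-atom bicyclic group at the same aromatic carbon gives a 1.7-fold higher number from compound 2 to compound 3 (0.23 log units; within the scatter). Among the measured compounds shown here, compound 3 therefore stands within the scatter of compound 2, and these two are the only exact numbers available.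

Compound 4 `CC(=O)N[C@@H]1CCC[C@H](C(=O)Nc2cc(-c3cnn4c3NCCC4)c(Cl)cn2)C1` keeps the chloro group and changes that bicyclic group again: a group of 9 heavy atoms (6 carbon, 3 nitrogen; one five-membered aromatic ring with 2 hetero atoms, one six-membered non-aromatic ring with 2 hetero atoms) in place of a group of 9 heavy atoms (6 carbon, 3 nitrogen; one five-membered aromatic ring with 3 hetero atoms, one six-membered aromatic ring with 1 hetero atom), on an aromatic carbon. For the measured compounds named here, the chloro step does not bear on this change, so the closest precedent is the earlier exchange at this position, which stayed within the scatter at a 1.7-fold higher number from compound 2 to compound 3 (0.23 log units; within the scatter). In this assay, no step beyond the scatter is therefore expected, and the estimated change is a 1.3-fold lower number from compound 3 to compound 4 (0.12 log units; within the scatter). Compound 4 is expected to give 400000 nM, within an estimated range of 150000 nM to 1000000 nM.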

Compound 4, solubility: 860000 nM
Estimate against measurement, compound 4: 2.2-fold (0.33 log units) below; measured number inside the range.
By their numbers in this assay, from the lowest: compounds 2, 3 and 4 (each within the scatter of the next, the first and the last beyond it). At a limit, above all of these: compound 1.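

In this assay, the exchange at this aromatic carbon, opposite the ring nitrogen, gives a 1.6-fold higher number from compound 3 to compound 4 (0.21 log units; within the scatter), while the comparison with the other non-aromatic bicyclic group gives a 2.8-fold higher number from compound 2 to compound 4 (0.44 log units; beyond the scatter). This is the first exchange at this position shown to go beyond the scatter, and the group that enters differs from the group in compound 3 by carrying 1 hydrogen-bond donor. Among the compounds shown here, with the chloro group kept throughout, the bicyclic group alone can therefore move the number beyond the scatter, although only the pair of compound 2 and compound 4 shows this.

On these data alone, compound 1 gives a limit and not a number: the limit of > 1000000 nM in this assay, at which 1 of the 4 values shown sits. Still open is how the group in compound 4 reads with fluoro in place of chloro, or with a methyl group or an ether oxygen in its non-aromatic ring.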